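The source may hold more compounds than are shown below. What is called first, only, known or untested is meant among the compounds shown, and "the series" means these compounds.

Compound 1 `C/C(=N\NC(=S)Nc1ccccc1I)c1ccccn1` gives 4.1 nM
Compound 2 `CC(=NNC(=S)Nc1cccc([N+](=O)[O-])c1)c1ccccn1` gives 38 nM
Compound 3 `C/C(=N\NC(=S)Nc1cccc(F)c1)c1ccccn1` gives 9 nM

In a functional assay on MCF7 cells (Homo sapiens) for cytotoxicity, read by MTT assay, with a stated time of 48 h (on this read-out higher numbers stand for weaker inhibition and lower numbers for stronger inhibition), compound 3 holds the middle place of the three. Compound 1 has a lower number and compound 2 a higher one, and both gaps lie beyond the usual scatter. Compound 4 `CC(=NNC(=S)Nc1cccc(F)c1)c1ccccn1` has the same atoms and bonds as compound 3 and differs only in how one double bond is drawn (the two compounds have the same atoms and bonds; at least one stereo element is drawn with a configuration in one of them and without one in the other: 1 of 1 stereo elements differ; a double bond is drawn E in compound 3 and without a configuration in compound 4). For the measured compounds named here, no pair of measured compounds shows what such a difference does. With the structure otherwise unchanged, no step beyond the scatter is expected in this assay in either direction. The expected change is no change at the digits printed from compound 3 to compound 4 (within the scatter) and it is only an estimate. The estimated value for compound 4 is 9 nM (expected range 5 nM to 16 nM).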

Compound 4, half-maximal inhibitory concentration: 9 nM
The estimate for compound 4 equals the measured number at the digits printed, within the range that was stated.
By their numbers in this assay, from the lowest: compound 1; then compounds 3 and 4 (each within the scatter of the next); then compound 2.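

In this assay, the change in how the double bond is drawn gives no change at the digits printed from compound 3 to compound 4 (within the scatter), so leaving its configuration undefined shifts nothing that can be told from the scatter. The only thing that separates these two entries is this: the fact that one of compounds 3 and 4 is drawn with a defined configuration and the other without, at the place where they differ. For the compounds shown here, with fluoro in place of nitro on an aromatic carbon, a single change that the earlier compounds did not isolate, the result is a 4.2-fold lower number from compound 2 to compound 4 (0.63 log units; beyond the scatter).

The compounds shown leave open which form of the double bond the undrawn entry contains, and how a form drawn Z would behave. They also leave open how an amine or a carboxylic acid on that aromatic carbon would compare with fluoro and nitro.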